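Nitroimidazo-oxazine series: liver microsome stability, step to compound 4

The source may report more compounds than this note shows. Statements on the series, on what has been measured and on what is new or still open speak of the compounds shown alone.

Measured compounds:
- Compound 1, `O=[N+]([O-])c1cn2c(n1)OC[C@@H](OCc1ccc(-c3ccccc3OCCCO)cc1)C2`: in an ADME assay on microsomes from liver (Mus musculus, strain CD1) for metabolic stability, read by LC-MS, with a stated time of 1 h (on this read-out lower numbers stand for a less stable compound and higher numbers for a more stable compound), compound 1 gives 21%.
- Compound 2, `O=[N+]([O-])c1cn2c(n1)OC[C@@H](OCc1ccc(-c3cccc(OCc4ccccc4)c3)cc1)C2`: in this assay compound 2 gives 50%.
- Compound 3, `O=[N+]([O-])c1cn2c(n1)OC[C@@H](OCc1ccc(-c3ccc(CNc4ccccc4)cc3)cc1)C2`: in this assay compound 3 gives 52%.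

Compound 3 holds the highest number of the three in this assay. Its gap to compound 2 lies within the usual scatter, so the two cannot be ranked against each other; its gap to compound 1 lies beyond the scatter, and compound 1 is the one clearly lower of the set.

Compound 4, `O=[N+]([O-])c1cn2c(n1)OC[C@@H](OCc1ccc(-c3ccc(Oc4ccccc4)cc3)cc1)C2`, has not been measured in this assay. It differs from compound 3 in one place: phenoxy in place of anilinomethyl on an aromatic carbon. The group that leaves carries one hydrogen-bond donor, the group that enters carries none; both keep one six-membered aromatic ring of carbon only, and the change sits para to a large group as printed in the place description.

For the measured compounds named here, no pair of measured compounds differs in a single place, so no measured step is available to set the size of this change. Against that background the expected step in this assay is small, a number 6 percentage points higher from compound 3 to compound 4 (within the scatter), in the direction of a somewhat higher number but not clearly beyond the scatter. For compound 4 the estimate in this assay is 58%, with a range from 40% to 76%.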

Compound 4, percent of the compound remaining: 48%
The estimate for compound 4 lay 10 percentage points above the measured number; the range from low to high includes it.
By their numbers in this assay, from the lowest: compound 1; then compounds 4, 2 and 3 (each within the scatter of the next).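

Phenoxy in place of anilinomethyl, on an aromatic carbon para to a large group, gives the first single-place step of the series: in this assay, a number 4 percentage points lower from compound 3 to compound 4 (within the scatter). This step cannot be told apart from no change, so at this position the read-out of percent remaining shows no response to this exchange, although the hydrogen-bond donor counted in anilinomethyl is absent from phenoxy. No measurement at hand explains this outcome or ties it to any property of either group.

This single exchange cannot show whether the same position would respond to a group of a different kind, such as a carboxylic acid, a basic aminomethyl group or a longer chain ending in a hydroxyl group. As far as these compounds go, compound 1, at 21%, differs from compound 3 and compound 4 in more than one place, so what sets its number apart from theirs in this assay also remains open, and a single-place step linking it to the others would be needed to resolve this.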